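Chalcone series on gastric cancer cells: benzyl to isopentyl ether

The compounds below may be only part of what the source reports. "The series", "measured", "known", "first", "only" and "open" are said of these compounds alone.

Measured compounds in a functional assay on NUGC-3 cells (Homo sapiens) for antiproliferative activity, read by sulforhodamine B assay; on this read-out lower numbers stand for stronger inhibition of growth and higher numbers for weaker inhibition of growth:
- compound 1, `COc1cccc(OCCC(C)(C)C)c1C(=O)/C=C/c1ccc(O)cc1`: > 30000 nM.
- compound 2, `O=C(/C=C/c1ccc(O)cc1)c1c(O)cccc1OCc1ccccc1`: > 30000 nM.
- compound 3, `CC(C)(C)CCOc1cccc(O)c1C(=O)CCc1ccc(O)cc1`: > 30000 nM.

For compound 2 this assay gives > 30000 nM, which is a limit of the assay and not a number. The same holds for compound 1 and for compound 3, each of which also sits at a limit. Compound 2 therefore cannot be placed against the other two on the numbers shown; all three rest on the limit of > 30000 nM in this assay, at which 3 of the 3 values shown sit, and nothing distinguishes them.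

Compound 4, `CC(C)CCOc1cccc(O)c1C(=O)/C=C/c1ccc(O)cc1`, differs from compound 2 by isobutyl in place of phenyl on a saturated chain carbon bound to an oxygen on an aromatic ring. Nothing measured speaks for this change moving the read-out beyond the scatter in either direction, since every value in hand is a limit. Compound 4 is expected to remain at a limit as well, with the step of a number no higher from compound 2 to compound 4 (the limit leaves the size open) estimated as none beyond the scatter. For compound 4 the estimate in this assay is 30000 nM, in the range 10000 nM to 100000 nM.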

Compound 4, concentration for 50% growth inhibition: 12400 nM
For compound 4 the middle estimate is 2.4-fold (0.38 log units) above the measured one, and the stated range covers the measured number.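

In this assay, among these compounds, isobutyl in place of phenyl on a saturated chain carbon bound to an oxygen on an aromatic ring gives an at least 2.4-fold lower number from compound 2 to compound 4 (0.38 log units; beyond the scatter), the only step that can be read. Compound 4, at 12400 nM, thus shows that this place on the ether can carry a measurable growth-inhibiting effect, and that benzyloxy to isopentyloxy is a change the read-out responds to. The full size of the step stays open, since the value for compound 2 is a limit and not a number: the limit of > 30000 nM in this assay, at which 3 of the 4 values shown sit.

As far as these compounds go, whether a longer chain, or a chain carrying an amine, in place of isopentyl would lower the number further remains open. Compound 1 and compound 3 each differ from compound 4 in more than one place, so the share of each of those differences also remains unresolved.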